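The compounds below may be only part of what the source reports. "The series", "measured", "known", "first", "only" and "open" are said of these compounds alone.

Measured in an ADME assay on BJ cells (Homo sapiens) for cytotoxicity, with a stated time of 72 h; on this read-out lower numbers stand for an effect already at smaller amounts and higher numbers for an effect only at larger amounts of compound:
- Compound 1 `O=C(Nc1ccc(F)c(-c2nc3ccccc3o2)c1)c1cc([N+](=O)[O-])ccc1Cl`: > 25000 nM
- Compound 2 `Cc1ccc(-c2nc3ccccc3s2)cc1NC(=O)c1cc([N+](=O)[O-])c(N(C)C)cc1Cl`: > 25000 nM
- Compound 3 `Cc1cc(NC(=O)c2cc([N+](=O)[O-])ccc2Cl)cc(-c2nc3ccccc3s2)c1O`: > 25000 nM

Each of these readings is a limit of the assay and not a number. Compound 2 stands where the others stand, at the limit of > 25000 nM in this assay, at which 3 of the 3 values shown sit.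

Compound 4 `Cc1ccc(-c2nc3ccccc3s2)cc1NC(=O)c1cc([N+](=O)[O-])c(N2CCCCC2)cc1Cl` differs from compound 2 in one place: piperidin-1-yl in place of dimethylamino on an aromatic carbon, ortho to a nitro group and meta to a chloro group (piperidin-1-yl in place of dimethylamino on an aromatic carbon). Among the compounds with values here, no measured pair differs in only one place, so the size of this step has no direct precedent.

In this assay no change beyond the usual scatter is expected. This expectation rests on compound 2, whose reading is the limit > 25000 nM. The expected change is a number no higher from compound 2 to compound 4 (the limit leaves the size open), with no direction expected, and a further reading at the limit is the likeliest outcome. For compound 4 the estimated value is 25000 nM, with an expected range of 12000 nM to 50000 nM.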

Compound 4, half-maximal effective concentration: > 25000 nM
Compound 4: no number, only a limit (the forecaster's own chance of this, stated with the estimate: 80%); the middle value lies on the limit itself.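

Compound 2 and compound 4 both sit at a limit of the assay rather than at a number, so the step from dimethylamino to piperidin-1-yl cannot be read. The compounds shown leave open at what concentration, if any, this series would give a measurable value in this assay.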